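The source may hold more compounds than are shown below. What is called first, only, known or untested is meant among the compounds shown, and "the series" means these compounds.

Of the compounds shown here, three that share one core have been tested in an ADME assay on Raji cells (Homo sapiens) for cytotoxicity, read by CellTiter-Glo and resazurin assay, with a stated time of 72 h (on this read-out lower numbers stand for an effect already at smaller amounts and higher numbers for an effect only at larger amounts of compound), and a fourth awaits its turn. Compound 1 `CCOC(=O)CCCCCOc1cccc(CN(C(=O)c2ccccc2)C(C)C)c1` carries hydrogen on the aromatic carbon where the others carry a group; in this assay compound 1 gives > 26000 nM, which is a limit of the assay rather than a number. Compound 2 `CCOC(=O)CCCCCOc1cccc(CN(C(=O)c2ccc(-c3cccnc3)cc2)C(C)C)c1` carries pyridin-3-yl there; in this assay compound 2 gives > 26000 nM, again a limit. Compound 3 `CCOC(=O)CCCCCOc1cccc(CN(C(=O)c2ccc(-c3cccc(OC(C)C)c3)cc2)C(C)C)c1` carries 3-isopropoxyphenyl instead; in this assay compound 3 gives > 26000 nM, also a limit. Compound 3 therefore stands where both others stand, at the limit of > 26000 nM in this assay, at which 3 of the 3 values shown sit. The step that the two limits leave unreadable from compound 1 to compound 2, the step that the two limits leave unreadable from compound 1 to compound 3 and the step that the two limits leave unreadable from compound 2 to compound 3 are all unreadable, since each compares two limits. Compound 4 `CCOC(=O)CCCCCOc1cccc(CN(C(=O)c2ccc(-c3ccc4[nH]ccc4c3)cc2)C(C)C)c1` differs from compound 3 by 1H-indol-5-yl in place of 3-isopropoxyphenyl on an aromatic carbon. Going by the values given here, none of the measured steps shows whether exchanging the group on this aromatic carbon moves the read-out; all of them only show that no compound has produced an effect within the amounts tested. The expectation is that this change gives no readable step either, so the step that the limit leaves unreadable from compound 3 to compound 4 is estimated. Compound 4 is expected to give 30000 nM, with a range from 15000 nM to 100000 nM, most likely again reported only as a limit.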

Compound 4, half-maximal effective concentration: > 26000 nM
Compound 4 ended at the assay's limit; the forecaster's own chance of this, stated with the estimate: 85%; the middle value lies beyond the limit too.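

In this assay compound 4 gives > 26000 nM, which is a limit and not a number. The steps to compound 4 from compound 1, compound 2 and compound 3 therefore cannot be read, since each compares two limits: the limit of > 26000 nM in this assay, at which 4 of the 4 values shown sit.

The compounds shown leave open whether exchanging the group on this aromatic carbon changes the read-out at all.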